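This account rests on a few compounds, and the source may have more. Where it says the series, first, only, none or still open, it means among the compounds named here.

Measured so far in a functional assay (muscle tissue) with Cavia porcellus as the target; on this read-out lower numbers stand for an effect already at smaller amounts and higher numbers for an effect only at larger amounts of compound:
compound 1, `COC(=O)C1=C(C)N=C(C)/C(=C(\O)OC)C1c1ccccc1C#N`: 15.9 nM
compound 2, `COC(=O)C1=C(C)N=C(C)/C(=C(\O)OC)C1c1cccc(C)c1`: 110 nM
compound 3, `COC(=O)C1=C(C)N=C(C)/C(=C(\O)OC)C1c1ccc(Br)cc1`: 540 nM

Compound 3 gives the highest number of the three in this assay. The gap from compound 2 is a 4.9-fold higher number from compound 2 to compound 3 (0.69 log units; beyond the scatter); the gap from compound 1 is a 34-fold higher number from compound 1 to compound 3 (1.53 log units; beyond the scatter). Both steps lie beyond the scatter, so compound 3 is the weakest of the measured compounds.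

Compound 4, `COC(=O)C1=C(C)N=C(C)/C(=C(\O)OC)C1c1ccccc1OC`, has not been measured. It differs from compound 3 in one place: 2-methoxyphenyl in place of 4-bromophenyl on a saturated ring carbon. The step that bears most on it is a 34-fold higher number from compound 1 to compound 3 (1.53 log units; beyond the scatter), where 2-cyanophenyl stood in place of 4-bromophenyl on the same saturated ring carbon. That step was large. Among the compounds with values here, the 2-methoxyphenyl of compound 4 shares its substitution pattern with the 2-cyanophenyl of compound 1 but carries a different group, and no measured pair tests a cyano-to-methoxy exchange, so the full size of a 34-fold higher number from compound 1 to compound 3 (1.53 log units; beyond the scatter) should not be carried over. A lower number than compound 3 in this assay is nonetheless expected, with a step of roughly the size of a 4.9-fold higher number from compound 2 to compound 3 (0.69 log units; beyond the scatter) to somewhat more.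

Estimated for compound 4 in this assay: 45 nM, range 12 nM to 170 nM, corresponding to an expected step of a 12-fold lower number from compound 3 to compound 4 (1.08 log units; beyond the scatter).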

Compound 4, half-maximal effective concentration: 57.5 nM
Estimate against measurement, compound 4: 1.3-fold (0.11 log units) below; low and high end bracket the measured number.
By their numbers in this assay, from the lowest: compound 1; then compounds 4 and 2 (each within the scatter of the next); then compound 3.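

In this assay, the step of a 9.4-fold lower number from compound 3 to compound 4 (0.97 log units; beyond the scatter) shows that a low number on this saturated ring carbon does not depend on the 2-cyanophenyl group alone: a 2-methoxyphenyl group, with a different substituent on the phenyl ring, also lies well below the 4-bromophenyl group of compound 3. Within the data shown here, the group on the aromatic carbon still counts, since the first direct exchange of cyano for methoxy gives a 3.6-fold higher number from compound 1 to compound 4 (0.56 log units; beyond the scatter), which leaves compound 1 with the lowest number of the series, while the step of a 1.9-fold lower number from compound 2 to compound 4 (0.28 log units; within the scatter) does not separate the 2-methoxyphenyl group from the 3-methylphenyl group of compound 2. No measured property of these compounds is available to account for these differences.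

Still open is how much of the spread belongs to the place on the phenyl ring and how much to the group itself, since each compound shown pairs one group with one place. Also open, on these data alone, is where an amine or a carboxylic acid on that phenyl ring would fall relative to the four numbers in hand.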